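This account rests on a few compounds, and the source may have more. Where it says the series, first, only, none or still open, it means among the compounds named here.

Among the measured compounds shown here, compound 2 `Cc1ccc(/C=C/C=N/NC(=O)CN2C(=O)N(c3ccc(Cl)cc3)C(N(O)C(=O)Nc3ccc(Cl)cc3)C2(C)C)o1` gives 32 nM in a physicochemical assay for solubility, read by LC-MS, measured as thermodynamic solubility, with a stated time of 24 h (a higher number here means a more soluble compound, a lower number a less soluble compound), and stands lowest of the two numbers so far; its nearest neighbour, compound 1 `COCCOc1ccc(N2C(=O)N(CC(=O)N/N=C/C=C/c3ccc(C)o3)C(C)(C)C2N(O)C(=O)Nc2ccc(Cl)cc2)cc1`, gives 2800 nM in this assay. For the measured compounds named here, the single measured step between them, an 88-fold lower number from compound 1 to compound 2 (1.94 log units; beyond the scatter), is large and beyond the scatter. Compound 3 `COCCOc1ccc(NC(=O)N(O)C2N(c3ccc(Cl)cc3)C(=O)N(CC(=O)N/N=C/C=C/c3ccc(C)o3)C2(C)C)cc1` remains unmeasured; it differs from compound 2 by 2-methoxyethoxy in place of chloro on an aromatic carbon. This is the reverse of the measured exchange, but carried out on the other aryl ring of the shared core, so the step from compound 1 to compound 2 bears on it only by analogy. Since that exchange gave an 88-fold lower number from compound 1 to compound 2 (1.94 log units; beyond the scatter), the reverse exchange here is expected to raise the number, though the size is uncertain given the different aromatic carbon involved. For compound 3 in this assay a rise of about a 38-fold higher number from compound 2 to compound 3 (1.57 log units; beyond the scatter) is expected, giving an estimated 1200 nM with a range of 250 nM to 6000 nM.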

Compound 3, solubility: 2300 nM
Compound 3: the middle estimate sits 1.9-fold (0.28 log units) below what was measured; the range from low to high includes it.
By their numbers in this assay, from the lowest: compound 2; then compounds 3 and 1 (each within the scatter of the next).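

Exchanging chloro for 2-methoxyethoxy, para to a large group on the (4-chlorophenyl)amino side, gives a 72-fold higher number from compound 2 to compound 3 (1.86 log units; beyond the scatter) in this assay; the exchange on the other aryl ring gave an 88-fold lower number from compound 1 to compound 2 (1.94 log units; beyond the scatter) in the opposite direction, so this pair of groups is now tied to a large step at two places on the shared core. In this assay compound 1 and compound 3, which carry 2-methoxyethoxy on different aryl rings, stand within the scatter of each other. Nothing measured here bears on the reason for the step.

On these data alone, whether the step belongs to 2-methoxyethoxy itself remains open, as a methoxy group or a morpholine at the same aromatic carbon would test that. The compounds also leave open what 2-methoxyethoxy on both aryl rings would give.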